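Aryl ether swap on the shared core

A few compounds are considered here, and "the series" means these few. Any claim that something is new, unique, unknown or untested is made for them only; others in the source may bear on it.

Compound 1 `CN(C)c1cccc(Oc2ccc3c(NCCCNCc4ccco4)ccnc3c2)c1` gives 9.28 in a physicochemical assay for acid dissociation. Compound 3 `COc1ccc(F)cc1CNCCCNc1ccnc2cc(Oc3cccc(N(C)C)c3)ccc12` gives 9.28, and compound 2 `COc1cccc(CNCCCNc2ccnc3cc(CCC(C)C)ccc23)c1O` gives 9.47; compound 1 and compound 3 are level at the digits shown, together the lowest of the three, and compound 2 is within the scatter of both. Among the compounds with values here, the one measured step, no change at the digits printed from compound 1 to compound 3 (within the scatter), concerns the group on the saturated chain carbon bound to an amine nitrogen, not the aryl ether. Compound 4 `Clc1ccc(Oc2ccc3c(NCCCNCc4ccco4)ccnc3c2)cc1` differs from compound 1 by 4-chlorophenyl in place of 3-(dimethylamino)phenyl on an oxygen on an aromatic ring. Within the data shown here, no measured step touches this place, so no shift beyond the scatter is expected, and the estimated step of a number 0.02 log units higher from compound 1 to compound 4 (within the scatter) is small. For compound 4 the expected value is 9.3, range 9 to 9.6.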

Compound 4, acid dissociation constant: 9.28
Compound 4: the middle estimate sits 0.02 log units above what was measured, within the range that was stated.
By their numbers in this assay, from the lowest: compounds 1, 3, 4 and 2 (each within the scatter of the next).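

Within the data shown here, at the aryl ether position, the exchange of 3-(dimethylamino)phenyl for 4-chlorophenyl reads as no change at the digits printed from compound 1 to compound 4 (within the scatter) in this assay and is the first measured step at this place. On the furan-2-yl side chain, this one pair therefore shows that the read-out tolerates loss of the dimethylamino group with no shift beyond the scatter. No measurement here bears on why the step reads this way.

Open, as far as these compounds go, is whether a carboxylic acid or a primary amine on the phenoxy ring would shift the number. Also open, from the compounds shown here alone, is whether the result carries over to the 5-fluoro-2-methoxyphenyl side chain of compound 3.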